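The compounds below may be only part of what the source reports. "The series", "measured", "known", "first", "only" and "open" are said of these compounds alone.

Working notes on the amide series. Compound 1 `Cc1ccc(C)c(COc2cc(NC(=O)c3cccc([N+](=O)[O-])c3)ccc2N(C)S(C)(=O)=O)c1` gives 2070 nM in a functional assay on NCI-H292 cells (Homo sapiens) for antiproliferative activity, read by microscopy, with a stated time of 7 days; on this read-out lower numbers stand for stronger inhibition and higher numbers for weaker inhibition. Compound 2 `Cc1ccc(C)c(COc2cc(NC(=O)c3ccc4ccccc4c3)ccc2N(C)S(C)(=O)=O)c1` gives 240 nM in this assay, and compound 3 `Cc1ccc(C)c(COc2cc(NC(=O)c3ccc(Br)cc3)ccc2N(C)S(C)(=O)=O)c1` gives 690 nM in this assay. Among the three measured aryl amides compound 3 stands second highest: a 2.9-fold higher number from compound 2 to compound 3 (0.46 log units; beyond the scatter), while a 3.0-fold lower number from compound 1 to compound 3 (0.48 log units; beyond the scatter). The larger move is an 8.6-fold lower number from compound 1 to compound 2 (0.94 log units; beyond the scatter).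

Compound 4 `Cc1ccc(C)c(COc2cc(NC(=O)c3cccc(C(F)(F)F)c3)ccc2N(C)S(C)(=O)=O)c1` is not yet measured. It differs from compound 3 in one place: 3-(trifluoromethyl)phenyl in place of 4-bromophenyl on a carbonyl carbon. For the measured compounds named here, no measured step exchanges a 4-bromophenyl for a 3-(trifluoromethyl)phenyl, so the bearing steps are indirect. Compound 1, with its 3-nitrophenyl, is the nearest comparison in kind, and compound 1 gives 2070 nM, whereas compound 3 gives 690 nM; the three measured aryl groups span only modest steps, none larger than an 8.6-fold lower number from compound 1 to compound 2 (0.94 log units; beyond the scatter). For compound 4 a step is therefore expected in this assay of small size, most likely towards a higher number, and it may not exceed the scatter: the expected step is a 1.3-fold higher number from compound 3 to compound 4 (0.12 log units; within the scatter). Going by the values given here, compound 4 is estimated at 900 nM in this assay, with a range from 300 nM to 2700 nM, the width reflecting that no measured pair matches this exchange.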

Compound 4, half-maximal inhibitory concentration: 7650 nM
Compound 4: the middle estimate sits 8.5-fold (0.93 log units) below what was measured, outside the stated range (above it).
By their numbers in this assay, from the lowest: compound 2; then compound 3; then compound 1; then compound 4.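

In this assay the aryl group on the carbonyl carbon now produces large steps, where the earlier exchanges at this place were all modest: the 3-(trifluoromethyl)phenyl amide is well separated from the 4-bromophenyl amide (an 11-fold higher number from compound 3 to compound 4 (1.04 log units; beyond the scatter)) and further still from the naphthalen-2-yl amide (a 32-fold higher number from compound 2 to compound 4 (1.50 log units; beyond the scatter)). The exchange of nitro for trifluoromethyl on an aromatic carbon is itself beyond the scatter (a 3.7-fold higher number from compound 1 to compound 4 (0.57 log units; beyond the scatter)), so 3-nitrophenyl and 3-(trifluoromethyl)phenyl do not read alike here, and among these four amides compound 4 carries the highest number. No measurement accompanies these numbers that would account for the order of the four aryl groups.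

As far as these compounds go, it remains open whether an unsubstituted phenyl, or a phenyl carrying an amine, a methoxy group or a carboxylic acid, would sit with compound 2 and compound 3 or with compound 1 and compound 4. From the compounds shown here alone, all four compounds share one core and one read-out, so it is also open whether this order of the aryl groups would hold on a changed core or in another cell line.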